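Hydroxy to methoxy on the oxime oxygen: one further step

A few compounds are considered here, and "the series" means these few. Any claim that something is new, unique, unknown or untested is made for them only; others in the source may bear on it.

Measured compounds:
compound 1 `CO/N=C(/CCN1CCN(c2ccccn2)CC1)c1ccc(Cl)cc1Cl` gives 65%
compound 2 `O/N=C(\CCCN1CCN(c2ccccn2)CC1)c1ccc(F)cc1` gives 62%
compound 3 `O/N=C(/CCCN1CCN(c2ccccn2)CC1)c1ccc(F)cc1` gives 65%

In a functional assay on HEK293 cells with D(4) dopamine receptor (Homo sapiens) as the target, read by FLIPR (on this read-out lower numbers stand for smaller maximal responses and higher numbers for larger maximal responses), compound 2 stands lowest of the three numbers, yet compound 1 and compound 3 both sit within the scatter of it. For the measured compounds named here, the only measured single-place step is a number 3 percentage points higher from compound 2 to compound 3 (within the scatter), a change in drawn configuration because of the fact that compounds 2 and 3 differ only in the configuration as drawn. Compound 4 `CO/N=C(\CCCN1CCN(c2ccccn2)CC1)c1ccc(F)cc1` differs from compound 2 by methyl in place of hydrogen on an oxygen. Going by the values given here, no measured step touches this oxygen; compound 1 also carries a methoxy but differs from compound 2 in more than one place, so only its value can be noted. With all shown differences inside the scatter, the expected step is a number 1 percentage points higher from compound 2 to compound 4 (within the scatter), none beyond the scatter. Compound 4 is therefore estimated at 63% (range 50% to 76%).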

Compound 4, largest response reached (reported as efficacy), in percent of the reference or control that the assay uses: 60%
Compound 4: middle estimate off by 3 percentage points, on the high side; the range from low to high includes it.
By their numbers in this assay, from the lowest: compounds 4, 2, 1 and 3 (each within the scatter of the next).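

In this assay, for the compounds shown here, methyl in place of hydrogen on the oxygen bonded to the double-bonded nitrogen gives a first direct reading at this position: a number 2 percentage points lower from compound 2 to compound 4 (within the scatter). Hydroxy to methoxy on this oxime, with the double bond drawn E, therefore leaves the maximal response within the scatter. Nothing available accounts for this outcome.

On these data alone, whether the same holds for the Z double bond of compound 3 remains open. So does the outcome with a longer group on this oxygen, such as ethyl or benzyl, or with a carboxylic acid there.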